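Dropping the methyl group from compound 2

The source may hold more compounds than are shown below. What is called first, only, known or untested is meant among the compounds shown, and "the series" means these compounds.

In a functional assay on B16-F10 cells (Mus musculus) for antiproliferative activity, read by MTT assay, with a stated time of 48 h (on this read-out lower numbers stand for stronger inhibition and higher numbers for weaker inhibition), compound 1 (`COc1ccc(/C=C/c2cc(OC)cc(OC)c2/C=C/C(=O)c2cccc(Br)c2)cc1`) gives 5.1 ug/mL and compound 2 (`COc1ccc(/C=C/c2cc(OC)cc(OC)c2/C=C/C(=O)c2ccccc2C)cc1`) gives 6.1 ug/mL. Within the data shown here, these are the only two numbers so far, and a 1.2-fold higher number from compound 1 to compound 2 (0.08 log units; within the scatter) lies within the scatter, so compound 2 is not separated from its sole neighbour. Compound 3 (`COc1ccc(/C=C/c2cc(OC)cc(OC)c2/C=C/C(=O)c2ccccc2)cc1`) follows from compound 2 by hydrogen in place of methyl on an aromatic carbon, ortho to a large group. Among the measured compounds shown here, only the one measured step bears on this change. For the measured compounds named here, it exchanged 3-bromophenyl for 2-methylphenyl on the same carbonyl carbon, and no measured pair isolates the methyl alone. No shift beyond the scatter is therefore expected, in either direction. The expected 1.0-fold lower number from compound 2 to compound 3 (0.01 log units; within the scatter) stays within the scatter. The estimate for compound 3 is 6 ug/mL, with an expected range from 3 ug/mL to 12 ug/mL.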

Compound 3, half-maximal inhibitory concentration: 3.7 ug/mL
Beside the measured number, compound 3's estimate is 1.6-fold (0.21 log units) above it; the range from low to high includes it.
By their numbers in this assay, from the lowest: compounds 3, 1 and 2 (each within the scatter of the next).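

In this assay, among these compounds, compound 3 isolates the methyl for the first time, with a 1.6-fold lower number from compound 2 to compound 3 (0.22 log units; within the scatter) as the step for hydrogen in place of methyl on an aromatic carbon, ortho to a large group. It also gives a direct reading for the bromo, with a 1.4-fold lower number from compound 1 to compound 3 (0.14 log units; within the scatter) for hydrogen in place of bromo, so neither substituent is separated from hydrogen on this read-out. No evidence on hand bears on the reason for this result.

Still open, from the compounds shown here alone, is whether an amine or a carboxylic acid on this ring would give a step beyond the scatter. Also open, going by these compounds, is whether replacing a methoxy group on the shared core with a longer chain would do so.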